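Swapping one aromatic group on the core of compound 1

A few compounds are considered here, and "the series" means these few. Any claim that something is new, unique, unknown or untested is made for them only; others in the source may bear on it.

Measured compounds:
compound 1 `O=C(NO)c1ccc(NCc2nc(-c3cc4ccccc4s3)nn2-c2ccccc2)cc1`, 65.5%
compound 2 `CNC(=O)c1ccc(NCc2nc(-c3ccccc3)nn2-c2ccccc2)cc1`, -3.6%

In an assay on Sf9 cells for inhibition of protein deacetylase HDAC6 (Homo sapiens), read by fluorescence, with a stated time of 40 min, tested at 100 nM (on this read-out lower numbers stand for less inhibition and higher numbers for more inhibition at the one concentration tested (going by the name of the read-out)), compound 1 stands highest of the two numbers, and compound 2 sits far below it, a gap beyond the usual scatter. Compound 3 `O=C(NO)c1ccc(NCc2nc(-c3ccccc3Cl)nn2-c2ccccc2)cc1` differs from compound 1 in one place: 2-chlorophenyl in place of 1-benzothiophen-2-yl on an aromatic carbon. Among the compounds with values here, no pair of measured compounds isolates this change, so its effect is not known from the data. The step of a number 15.5 percentage points lower from compound 1 to compound 3 (beyond the scatter) is expected to be a modest loss in this assay, though it could also fall within the scatter. Compound 3 is estimated at 50%, with a range from 25% to 72%.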

Compound 3, a percentage reported as inhibition, at one concentration (the size of the read-out at that concentration, not a potency): 75%
Compound 3: middle estimate off by 25 percentage points, on the low side, and the stated range ends below it.
By their numbers in this assay, from the lowest: compound 2; then compounds 1 and 3 (each within the scatter of the next).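

In this assay, placing 2-chlorophenyl in place of 1-benzothiophen-2-yl gives a number 9.5 percentage points higher from compound 1 to compound 3 (within the scatter). At this aromatic carbon, then, a single six-membered ring bearing chlorine reads alike with the larger two-ring group, so the five-membered sulfur ring is not required to keep this level of inhibition at the one concentration tested. Nothing available explains why the two groups read alike. From the compounds shown here alone, whether the chlorine itself contributes remains open, as does how a pyridyl ring or an amine would read at this carbon.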